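Trimming Ethyl to Methyl: Expected Receptor Binding of Compound 3

The compounds below may be only part of what the source reports. "The series", "measured", "known", "first", "only" and "open" are said of these compounds alone.

Measured so far:
Compound 1, `CCCN(c1nc(-c2cc(F)c(Cl)cc2Cl)n(C)n1)C(C1CC1)C1CC1`, gives 15 nM in an assay on CHO cells for binding affinity to corticotropin-releasing factor receptor 1 (Homo sapiens); on this read-out lower numbers stand for stronger inhibition and higher numbers for weaker inhibition.
Compound 2, `CCCN(c1nc(-c2c(C)cc(C)cc2C)n(CC)n1)C(C1CC1)C1CC1`, gives 310 nM in this assay.

Of these two, compound 2 has the higher number, and its gap to compound 1 lies beyond the usual scatter. Compound 3, `CCCN(c1nc(-c2c(C)cc(C)cc2C)n(C)n1)C(C1CC1)C1CC1`, is not yet measured. It differs from compound 2 in a single place: hydrogen in place of methyl on a saturated chain carbon bound to an aromatic nitrogen; read one bond further out, the change is ethyl to methyl. Going by the values given here, no measured pair shows this change alone. Compound 1 carries the methyl, but it also carries a different aromatic ring, so its number cannot be split between the two changes. The expectation is that compound 3 lands close to compound 2, with a small step of a 1.6-fold lower number from compound 2 to compound 3 (0.19 log units; within the scatter) in this assay that may stay within the scatter. For compound 3 the estimate is 200 nM, with a range from 60 nM to 650 nM.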

Compound 3, inhibition constant: 120 nM
Beside the measured number, compound 3's estimate is 1.7-fold (0.22 log units) above it; the measured number falls inside the stated range.
By their numbers in this assay, from the lowest: compound 1; then compound 3; then compound 2.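

Cutting ethyl to methyl on the aromatic nitrogen gives a 2.6-fold lower number from compound 2 to compound 3 (0.41 log units; beyond the scatter) in this assay and so shows this change on its own for the first time. The step is modest, but it shows that binding at this position responds to the loss of one carbon. In this assay compound 1 gives 15 nM and compound 3 gives 120 nM with the same methyl on that nitrogen, so the gap that remains between these two sits in the aromatic ring.

One step gives a direction for this pair only, and the compounds shown leave open how a propyl chain or a chain ending in an amine would read at this position. Nothing available explains why the shorter group gives the lower number.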